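Trimethoxyphenyl oxadiazoline versus hydrazone: aryl swap on compound 1

The compounds below may be only part of what the source reports. "The series", "measured", "known", "first", "only" and "open" are said of these compounds alone.

Measured compounds:
compound 1 `COc1cc(C2=NN(C(C)=O)C(c3ccc(F)cc3)O2)cc(OC)c1OC`: -0.4%
compound 2 `COc1cc(C(=O)N/N=C/c2ccc(F)cc2)cc(OC)c1OC`: 50.9%
compound 3 `COc1cc(C(=O)N/N=C/c2ccc(Cl)c(Cl)c2)cc(OC)c1OC`: 29.6%

In a functional assay on BGC-823 cells (Homo sapiens) for antiproliferative activity, read by MTT assay, tested at 1 uM (on this read-out lower numbers stand for a weaker effect and higher numbers for a stronger effect at the one concentration tested), compound 1 gives -0.4%, the lowest of the three numbers and beyond the scatter from both others. Among the compounds with values here, compound 2 gives 50.9%, compound 3 gives 29.6%; the one measured step, a number 21.3 percentage points lower from compound 2 to compound 3 (beyond the scatter), belongs to the open-chain pair and not to the core of compound 1.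

Compound 4 `COc1cc(C2=NN(C(C)=O)C(c3cccc(C(F)(F)F)c3)O2)cc(OC)c1OC` differs from compound 1 by 3-(trifluoromethyl)phenyl in place of 4-fluorophenyl on a saturated ring carbon. Within the data shown here, only the step from compound 2 to compound 3 bears on this, and only loosely: it shows a different aryl change on a different carbon, and that step was modest. Nothing measured shows that an aryl swap on the saturated ring carbon lifts the core of compound 1 off its near-zero reading. The expected step is therefore small, a number 6.4 percentage points higher from compound 1 to compound 4 (within the scatter), within or barely beyond the scatter. Compound 4 is estimated at 6%, in the range -10% to 25%.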

Compound 4, a percentage reported as inhibition, at one concentration (the size of the read-out at that concentration, not a potency): 27.9%
Compound 4: middle estimate off by 21.9 percentage points, on the low side, outside the stated range (above it).
By their numbers in this assay, from the lowest: compound 1; then compounds 4 and 3 (each within the scatter of the next); then compound 2.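

The step of a number 28.3 percentage points higher from compound 1 to compound 4 (beyond the scatter) shows that in this assay the saturated ring carbon of the core of compound 1 is not a silent position: the aryl group placed there can move the read-out beyond the scatter. Compound 4 keeps the shared core unchanged. With that core, the near-zero reading is seen for compound 1 and not for compound 4. Nothing on hand accounts for the gain, and this single change swaps both the substituent and its place on the phenyl ring, so neither part can be credited separately.

The compounds shown leave open whether 4-(trifluoromethyl)phenyl or 3-fluorophenyl on the same carbon would separate those two parts. Also open, going by these compounds, is whether a propanoyl group in place of the acetyl group would shift the reading of compound 4.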